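A few compounds are considered here, and "the series" means these few. Any claim that something is new, unique, unknown or untested is made for them only; others in the source may bear on it.

Of the compounds shown here, two built on a shared core have been measured so far. In a functional assay on MCF7 cells (Homo sapiens) for cytotoxicity, read by MTT assay, with a stated time of 72 h (on this read-out higher numbers stand for weaker inhibition and lower numbers for stronger inhibition), compound 1 `CNC(=O)c1cc(Oc2ccc(/C=C/C(=O)c3ccc(Br)cc3)cc2)ccn1` gives 7100 nM and compound 2 `CNC(=O)c1cc(Oc2ccc(/C=C/C(=O)c3ccc([N+](=O)[O-])cc3)cc2)ccn1` gives 54300 nM on the same scale. Compound 2 holds the higher of the two numbers, which makes it the weaker inhibitor of the pair. Among the measured compounds shown here, the single measured step is a 7.6-fold higher number from compound 1 to compound 2 (0.88 log units; beyond the scatter) and it comes with nitro in place of bromo on an aromatic carbon.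

Compound 3 `CNC(=O)c1cc(Oc2ccc(/C=C/C(=O)c3ccc(Cl)cc3)cc2)ccn1` has chloro in place of nitro on an aromatic carbon, para to a large group, and the change is chloro in place of nitro on an aromatic carbon in full. For the measured compounds named here, no chloro compound has a measured number yet, so the only guide is that same step read backwards. Chloro and the bromo of compound 1 are both halogens, so compound 3 is expected to land near compound 1 at 7100 nM and to undo most of a 7.6-fold higher number from compound 1 to compound 2 (0.88 log units; beyond the scatter) in this assay as a move towards stronger inhibition. The expected change is a 6.8-fold lower number from compound 2 to compound 3 (0.83 log units; beyond the scatter) on this evidence. Compound 3 is estimated at 8000 nM with an expected range from 3500 nM to 18000 nM as the likely span.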

Compound 3, half-maximal inhibitory concentration: 17500 nM
The estimate for compound 3 lay 2.2-fold (0.34 log units) below the measured number, within the range that was stated.
By their numbers in this assay, from the lowest: compound 1; then compound 3; then compound 2.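

In this assay the place on this aromatic ring, para to a large group, now has three groups to compare, and a 3.1-fold lower number from compound 2 to compound 3 (0.49 log units; beyond the scatter) shows that chloro recovers only part of the gap that separated nitro from bromo. The second step, a 2.5-fold higher number from compound 1 to compound 3 (0.39 log units; beyond the scatter), shows that the two halogens cannot be treated as interchangeable here, since bromo gives the lower number and the stronger inhibition of the pair. Among the compounds shown here, the order from the lowest number is therefore bromo, chloro, nitro, and this place distinguishes even between two closely related groups, which the single step from bromo to nitro could not reveal, while nothing available here accounts for that order.

Going by these compounds, three groups give an order but not a rule, so it remains open where fluoro, iodo, methoxy, an amine or a carboxylic acid would fall at this same place. On these data alone, it is also open whether bromo keeps its lead over chloro when the same swap is made on another part of the shared core, or when the methyl on the amide gives way to a longer chain.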